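The compounds below may be only part of what the source reports. "The series", "measured", "known", "first", "only" and "open" are said of these compounds alone.

In a functional assay on SF-268 cells (Homo sapiens) for antiproliferative activity, read by sulforhodamine B assay, with a stated time of 72 h (on this read-out higher numbers stand for weaker inhibition and lower numbers for stronger inhibition), compound 1 (`Cc1cc(C)nc(NS(=O)(=O)c2ccc(Nc3nncc4ccccc34)cc2)n1`) gives 7.6 nM and compound 2 (`Cc1cc(NS(=O)(=O)c2ccc(Nc3nncc4ccccc34)cc2)no1`) gives 24 nM, so compound 2 holds the higher of the two numbers. Compound 3 (`NS(=O)(=O)c1ccc(Nc2nncc3ccccc23)cc1`) differs from compound 2 by one change: hydrogen in place of 5-methyl-1,2-oxazol-3-yl on a sulfonamide nitrogen. Among the measured compounds shown here, the only measured step at this place is a 3.2-fold higher number from compound 1 to compound 2 (0.50 log units; beyond the scatter), a modest one that exchanges one group for another, and no measured compound lacks such a group. On that limited basis, a modest move toward weaker inhibition is expected, estimated as a 2.5-fold higher number from compound 2 to compound 3 (0.40 log units; beyond the scatter). The estimated value for compound 3 is 60 nM, within a range of 15 nM to 250 nM.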

Compound 3, half-maximal inhibitory concentration: 33 nM
The estimate for compound 3 lay 1.8-fold (0.26 log units) above the measured number; measured number inside the range.
By their numbers in this assay, from the lowest: compound 1; then compounds 2 and 3 (each within the scatter of the next).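

In this assay, replacing the 5-methyl-1,2-oxazol-3-yl group with hydrogen on the sulfonamide nitrogen gives no readable difference (a 1.4-fold higher number from compound 2 to compound 3 (0.14 log units; within the scatter)), so this group cannot be told apart from hydrogen at this position. The 4,6-dimethylpyrimidin-2-yl group does stand apart from hydrogen (a 4.3-fold higher number from compound 1 to compound 3 (0.64 log units; beyond the scatter)), which makes compound 1 the only one here separated from the unsubstituted sulfonamide. No evidence is available to explain why the two groups differ in this way.

On these data alone, whether a methyl, an acetyl or a phenyl group on this nitrogen would read like compound 1 or like compound 3 remains open.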